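The compounds below may be only part of what the source reports. "The series", "measured", "known", "first", "only" and "open" are said of these compounds alone.

In a functional assay on L1210 cells (Mus musculus) for inhibition (on this read-out higher numbers stand for weaker inhibition and lower numbers for stronger inhibition), compound 1 (`Nc1ncnc2c1ncn2C/C=C/CCl`) gives 45000 nM and compound 2 (`Nc1ccn(C/C=C/CCl)c(=O)n1`) gives 50000 nM, which are within the scatter of each other. Compound 3 (`Nc1ccn(C/C=C\CCl)c(=O)n1`) lies clearly lower (10000 nM).

Moving to compound 4 (`Nc1ncnc2c1ncn2C/C=C\CCl`), the change is the two compounds have the same atoms and bonds and differ only in configuration as drawn: 1 of 1 stereo elements differ; a double bond is drawn E in compound 1 and Z in compound 4 and nothing leaves or enters. For the measured compounds named here, one measured step bears on this, though on a different core: a 5.0-fold lower number from compound 2 to compound 3 (0.70 log units; beyond the scatter) with the fact that compounds 2 and 3 differ only in the configuration as drawn as its basis. That single step, the same double-bond change from E to Z, points to a drop of similar size and direction, beyond the scatter, and a 4.5-fold lower number from compound 1 to compound 4 (0.65 log units; beyond the scatter) is the step expected here. Compound 4 is therefore estimated at 10000 nM (expected range 3500 nM to 30000 nM).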

Compound 4, half-maximal inhibitory concentration: 22000 nM
For compound 4 the middle estimate is 2.2-fold (0.34 log units) below the measured one; the measured number falls inside the stated range.
By their numbers in this assay, from the lowest: compound 3; then compound 4; then compounds 1 and 2 (each within the scatter of the next).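

The drop on going from the E to the Z double bond now appears on a second core: a 2.0-fold lower number from compound 1 to compound 4 (0.31 log units; beyond the scatter), alongside a 5.0-fold lower number from compound 2 to compound 3 (0.70 log units; beyond the scatter) on the core of compound 2. Both steps lie beyond the scatter, so the direction of the change holds for both pairs shown. The new step rests on configuration alone: the fact that compounds 1 and 4 differ only in the configuration as drawn

Still open, from the compounds shown here alone, is whether the same direction holds with a bromine in place of the terminal chlorine or with a longer chain. Going by these compounds, whether it extends to cores other than these two is also open.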